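Acetamido in place of hydrogen on a sulfonyl chain

The compounds below may be only part of what the source reports. "The series", "measured", "known", "first", "only" and "open" are said of these compounds alone.

Among the compounds with values here, compound 2 `CCS(=O)(=O)NC(=O)c1ccc(Nc2nc(NC3(c4ccc(Cl)cc4)CC3)nc(OCC(F)(F)F)n2)cc1` gives 28 nm/s in a physicochemical assay for permeability, using PAMPA, at pH 7.4 (on this read-out lower numbers stand for lower permeability and higher numbers for higher permeability), the lower of the two numbers measured so far. Compound 1 `CC(C)(C)OC(=O)NCCS(=O)(=O)NC(=O)c1ccc(Nc2nc(NC3(c4ccc(Cl)cc4)CC3)nc(OCC(F)(F)F)n2)cc1` gives 111 nm/s. Within the data shown here, one measured step bears on the change: a 4.0-fold lower number from compound 1 to compound 2 (0.60 log units; beyond the scatter), a modest step beyond the scatter. Compound 3 `CC(=O)NCCS(=O)(=O)NC(=O)c1ccc(Nc2nc(NC3(c4ccc(Cl)cc4)CC3)nc(OCC(F)(F)F)n2)cc1` differs from compound 2 by acetamido in place of hydrogen on a saturated chain carbon, two bonds along the chain from a sulfonyl sulfur. The group entering here is smaller than the one removed in the measured step, so an upward step that is expected to be no larger than modest, a 1.6-fold higher number from compound 2 to compound 3 (0.21 log units; within the scatter), seems the likely outcome. Compound 3 is therefore estimated at 45 nm/s, within a range of 15 nm/s to 120 nm/s.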

Compound 3, apparent permeability: 7 nm/s
For compound 3 the middle estimate is 6.4-fold (0.81 log units) above the measured one; the measured number lies below the stated range.
By their numbers in this assay, from the lowest: compound 3; then compound 2; then compound 1.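

In this assay, acetamido on this chain carbon does not restore what hydrogen lost relative to the larger carbamate: the result is a 4.0-fold lower number from compound 2 to compound 3 (0.60 log units; beyond the scatter), so the numbers do not follow group size, and the compound carrying hydrogen falls in the middle. Methyl in place of tert-butoxy on the carbonyl carbon gives a 16-fold lower number from compound 1 to compound 3 (1.20 log units; beyond the scatter), the widest gap among the three compounds, so the group on that carbonyl matters strongly here. Nothing available explains these steps. As far as these compounds go, it remains open where a free amine, a carboxylic acid or a longer chain at this carbon would fall.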